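A few compounds are considered here, and "the series" means these few. Any claim that something is new, unique, unknown or untested is made for them only; others in the source may bear on it.

Of the compounds shown here, three built on one shared core have been tested in a functional assay on the whole organism with Canis familiaris (Canis lupus familiaris) as the target, at a dose of 8 mg/kg by the oral route; on this read-out higher numbers stand for a stronger effect at the one dose given and lower numbers for a weaker effect. Compound 1 `Cc1nc2c(OCc3ccccn3)cccn2c1N` carries a pyridin-2-yl group on a saturated chain carbon bound to an oxygen on an aromatic ring, and in this assay compound 1 gives 15%. In this assay compound 2 `Cc1nc2c(OCc3cccs3)cccn2c1N` gives 86%, and compound 3 `Cc1nc2c(OCc3ccsc3)cccn2c1N` gives 88%. Exchanging the ring on that chain carbon mattered a great deal: a number 71 percentage points higher from compound 1 to compound 2 (beyond the scatter) and a number 73 percentage points higher from compound 1 to compound 3 (beyond the scatter), whereas a number 2 percentage points higher from compound 2 to compound 3 (within the scatter). Compound 3 therefore holds the highest of the three numbers, with compound 2 within the scatter of it and compound 1 far beneath.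

Compound 4 `Cc1nc2c(Oc3ccccc3)cccn2c1N` has not yet been measured in this assay. Its change from compound 3 is phenyl in place of (thiophen-3-yl)methyl on an oxygen on an aromatic ring. Going by the values given here, no measured step bears directly on this: every step so far kept the saturated chain carbon and only exchanged the ring on it, with a large rise when pyridin-2-yl became thiophene and nothing beyond the scatter between the two thiophenes. Compound 4 instead removes the chain carbon and brings in a ring of carbon only, so the measured steps give no firm guide and a wide range is appropriate. Compound 4 is expected to give 45% in this assay, with a likely range from 10% to 85%. That estimate corresponds to an expected step of a number 43 percentage points lower from compound 3 to compound 4 (beyond the scatter).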

Compound 4, a percentage reported as inhibition, in the whole organism at one dose (the size of the read-out at that dose, not a potency): 19%
Compound 4: middle estimate off by 26 percentage points, on the high side; measured number inside the range.
By their numbers in this assay, from the lowest: compounds 1 and 4 (each within the scatter of the next); then compounds 2 and 3 (each within the scatter of the next).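

In this assay, putting phenyl on the oxygen on an aromatic ring in place of (thiophen-3-yl)methyl gives a number 69 percentage points lower from compound 3 to compound 4 (beyond the scatter) and putting it in place of (thiophen-2-yl)methyl gives a number 67 percentage points lower from compound 2 to compound 4 (beyond the scatter) as the outcome. Going by these compounds alone, every earlier step kept the saturated chain carbon and exchanged only the ring on it, so this is the first sign that the high numbers of the two thiophene compounds do not survive a change that removes that carbon and brings in a ring of carbon only, even though the groups that leave and the group that enters each count 6 heavy atoms. Nothing measured here explains why the number falls. Two things change at once in these steps, so the compounds shown cannot say whether the loss of the chain carbon or the loss of the thiophene ring matters more; a benzyl group, with phenyl back on the chain carbon, and a thiophene ring bound straight to the oxygen would pull the two apart. Also open, on these data alone, is whether a longer chain carrying a thiophene ring would keep the effect at this position.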